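The source may hold more compounds than are shown below. What is called first, only, known or untested is meant among the compounds shown, and "the series" means these compounds.

Compound 1 `Cc1ccc(Cn2cncc2-c2cc3cc(Br)ccc3[nH]2)cc1` gives 21600 nM in an assay on isolated protein for inhibition of Indoleamine 2,3-dioxygenase 1 (Homo sapiens), with a stated time of 1 h (on this read-out lower numbers stand for stronger inhibition and higher numbers for weaker inhibition), and compound 2 `N#Cc1ccc(Cn2cncc2-c2cc3cc(Br)ccc3[nH]2)cc1` gives 3810 nM. Compound 3 `Brc1ccc2[nH]c(-c3cncn3CC3CCCCN3)cc2c1` returns only the assay limit, > 100000 nM, so its position is marked by the limit of > 100000 nM in this assay, at which 1 of the 3 values shown sits, rather than a number. Compound 4 `Nc1ccccc1Cn1cncc1-c1cc2cc(Br)ccc2[nH]1` carries 2-aminophenyl in place of piperidin-2-yl on a saturated chain carbon bound to an aromatic nitrogen, which reverses the kind of change seen in the measured steps: an at least 4.6-fold higher number from compound 1 to compound 3 (0.66 log units; beyond the scatter) and an at least 26-fold higher number from compound 2 to compound 3 (1.41 log units; beyond the scatter), both beyond the scatter. Restoring an aromatic ring on the saturated chain carbon bound to the aromatic nitrogen is therefore expected to bring the number in this assay back down, by a step of about an at least 6.6-fold lower number from compound 3 to compound 4 (0.82 log units; beyond the scatter). Compound 4 is estimated at 15000 nM, with a range from 4000 nM to 60000 nM.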

Compound 4, half-maximal inhibitory concentration: 50600 nM
The estimate for compound 4 lay 3.4-fold (0.53 log units) below the measured number; the measured number falls inside the stated range.
By their numbers in this assay, from the lowest: compound 2; then compound 1; then compound 4. At a limit, above all of these: compound 3.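

Putting an aromatic ring back on this saturated chain carbon does not by itself give a low number in this assay and the choice of ring group counts: relative to 4-cyanophenyl and 4-methylphenyl, 2-aminophenyl brings a 13-fold higher number from compound 2 to compound 4 (1.12 log units; beyond the scatter) and a 2.3-fold higher number from compound 1 to compound 4 (0.37 log units; beyond the scatter) in this series. Against piperidin-2-yl the change reads only as an at least 1.9-fold lower number from compound 3 to compound 4 (0.29 log units; that floor lies within the scatter) and that floor lies within the scatter. Compound 3 is held at a limit and not a number: the limit of > 100000 nM in this assay, at which 1 of the 4 values shown sits.

How far 2-aminophenyl truly lies from piperidin-2-yl stays unsized. As far as these compounds go, whether a 4-aminophenyl group or a carboxylic acid on the ring would match compound 2 also stays open.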